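The source may hold more compounds than are shown below. What is called first, only, known or untested is meant among the compounds shown, and "the series" means these compounds.

Going by the values given here, compound 2 `CC(C)(C)NC(=O)NCCCOc1cccc(CN2CCCCC2)c1` gives 2090 nM in an assay on isolated protein for inhibition of histamine H2 receptor (Cavia porcellus) (a lower number here means tighter binding, a higher number weaker binding), the lower of the two numbers measured so far, though only by a margin that means nothing. Compound 1 `COc1ccc(NC(=O)NCCCOc2cccc(CN3CCCCC3)c2)c(OC)c1` carries a 2,4-dimethoxyphenyl group in place of the tert-butyl group on the amide-type nitrogen, and in this assay compound 1 gives 2240 nM. Among the compounds with values here, the step of a 1.1-fold lower number from compound 1 to compound 2 (0.03 log units; within the scatter) is the only measured comparison available, and it shows that exchanging a ring for a tert-butyl group at that nitrogen left the binding essentially unchanged. Compound 3 `O=C(NCCCOc1cccc(CN2CCCCC2)c1)Nc1cccc(Cl)c1` alters the same spot: 3-chlorophenyl in place of tert-butyl on an amide-type nitrogen. Since that earlier exchange a 1.1-fold lower number from compound 1 to compound 2 (0.03 log units; within the scatter) stayed within the scatter, putting a ring back at this nitrogen is expected to change little, and the expected step is a 1.0-fold lower number from compound 2 to compound 3 (0.02 log units; within the scatter). Compound 3 is therefore estimated at 2000 nM, with a likely range from 700 nM to 6000 nM.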

Compound 3, dissociation constant: 316 nM
Estimate against measurement, compound 3: 6.3-fold (0.80 log units) above, and the stated range ends above it.
By their numbers in this assay, from the lowest: compound 3; then compounds 2 and 1 (each within the scatter of the next).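

The group on this amide-type nitrogen does matter in this assay, with a 6.6-fold lower number from compound 2 to compound 3 (0.82 log units; beyond the scatter) and a 7.1-fold lower number from compound 1 to compound 3 (0.85 log units; beyond the scatter), although the earlier pair of compound 1 and compound 2 had made the position look indifferent. A ring alone is not enough: compound 1 also carries a ring there and stands within the scatter of compound 2, so the comparison points to the difference between 3-chlorophenyl and 2,4-dimethoxyphenyl. Nothing measured here says what lies behind that difference.

From the compounds shown here alone, whether the tighter binding of compound 3 depends on the chlorine remains open, and a plain phenyl or a 3-methoxyphenyl group on the same nitrogen would address that. It is also unknown whether the same exchange would hold up on a core with a longer chain.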